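The source may report more compounds than this note shows. Statements on the series, on what has been measured and on what is new or still open speak of the compounds shown alone.

Compound 1 `Nc1ncnn2c([C@@H]3O[C@H](CO)[C@@H](O)[C@H]3O)cc(-c3ccccc3)c12`: > 100000 nM (a limit, not a number)
Compound 2 `Nc1ncnn2c([C@@H]3O[C@H](CO)[C@@H](O)[C@H]3O)cc(-c3ccc(F)cc3F)c12`: 93300 nM
Compound 3 `Nc1ncnn2c([C@@H]3O[C@H](CO)[C@@H](O)[C@H]3O)cc(-c3ccsc3)c12`: 35600 nM

These results come from a functional assay on NCI-H460 cells (Homo sapiens) for antiproliferative activity, with a stated time of 72 h; on this read-out lower numbers stand for stronger inhibition and higher numbers for weaker inhibition. Compound 3 has the lowest number of the set, and the nearest number belongs to compound 2 at 93300 nM. The next structure, compound 4 `Nc1ncnn2c([C@@H]3O[C@H](CO)[C@@H](O)[C@H]3O)cc(-c3ccccc3Cl)c12`, carries 2-chlorophenyl in place of thiophen-3-yl on an aromatic carbon.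

Two measured steps made the opposite kind of swap, putting thiophen-3-yl onto the core in place of a benzene-type ring. They are a 2.6-fold lower number from compound 2 to compound 3 (0.42 log units; beyond the scatter) and an at least 2.8-fold lower number from compound 1 to compound 3 (0.44 log units; beyond the scatter), both beyond the usual scatter. Between the two phenyl compounds, the only measured step is an at least 1.0-fold lower number from compound 1 to compound 2 (0.03 log units; that floor lies within the scatter).

Compound 4 returns to a six-membered aromatic ring of carbon only, so the number in this assay is expected to rise modestly, in line with a 2.6-fold lower number from compound 2 to compound 3 (0.42 log units; beyond the scatter) read in reverse. The expected change is a 2.1-fold higher number from compound 3 to compound 4 (0.32 log units; beyond the scatter). The estimated value for compound 4 is 75000 nM, with an expected range of 35000 nM to 100000 nM.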

Compound 4, half-maximal inhibitory concentration: > 100000 nM
Compound 4: no number, only a limit; the forecaster's own chance of this, stated with the estimate: 35%; middle value at least 1.3-fold (0.12 log units) from the limit.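

In this assay, 2-chlorophenyl on this aromatic carbon gives an at least 2.8-fold higher number from compound 3 to compound 4 (0.44 log units; beyond the scatter), so among the compounds shown, all three groups with a six-membered aromatic ring of carbon only now lie beyond the scatter from thiophen-3-yl, and none goes against this. Against the other substituted ring, the result is an at least 1.0-fold higher number from compound 2 to compound 4 (0.03 log units; that floor lies within the scatter), a floor within the scatter, so no order can be stated between 2-chlorophenyl and 2,4-difluorophenyl. The step for chloro in place of hydrogen, from compound 1 to compound 4, cannot be read because both values are limits: the limit of > 100000 nM in this assay, at which 2 of the 4 values shown sit.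

From the compounds shown here alone, what a chloro group does to a measured number at this position therefore stays open. Going by these compounds, it is also open whether an amine or a carboxylic acid on this carbon would give a lower number than compound 3, at 35600 nM.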